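A few compounds are considered here, and "the series" means these few. Any claim that something is new, unique, unknown or untested is made for them only; others in the source may bear on it.

Compound 1 `CC1CCN(c2c(S(=O)(=O)c3ccc(Cl)c(Cl)c3)cnc3ccc(F)cc23)CC1` sets the reference point here. In an assay on isolated protein for displacement of a labelled ligand from metabotropic glutamate receptor 5 (Homo sapiens), with a stated time of 60 min, tested at 1 uM (on this read-out higher numbers stand for more inhibition at the one concentration tested (going by the name of the read-out) and lower numbers for less inhibition), compound 1 gives 91%. Compound 2 `CC1CCN(c2c(S(=O)(=O)c3ccc(Cl)cc3)cnc3ccc(F)cc23)CC1` carries a hydrogen where compound 1 carries a chloro, and in this assay compound 2 gives 80%. Going by the values given here, that single exchange produced a step of a number 11 percentage points lower from compound 1 to compound 2 (beyond the scatter), so compound 2 stands as the lower of the two numbers measured, with compound 1 as its only neighbour.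

Compound 3 `CC1CCN(c2c(S(=O)(=O)c3ccc(Cl)cc3)cnc3ccc(Cl)cc23)CC1` is the next compound, and it differs from compound 2 in one place: chloro in place of fluoro on an aromatic carbon. Among the compounds with values here, only one measured step exists, the one from compound 1 to compound 2, and it removed a chloro entirely rather than exchanging a fluoro for one, so it bears on the new change only loosely. Taken as a rough guide, it suggests that a chloro tends to sit on the higher side, so a small rise or a step within the scatter is expected for this assay, amounting to about a number 5 percentage points higher from compound 2 to compound 3 (within the scatter). Compound 3 is therefore estimated at 85%, with a range from 70% to 96%.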

Compound 3, a percentage reported as inhibition, at one concentration (the size of the read-out at that concentration, not a potency): 92%
Estimate against measurement, compound 3: 7 percentage points below; the measured number falls inside the stated range.
By their numbers in this assay, from the lowest: compound 2; then compounds 1 and 3 (each within the scatter of the next).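

In this assay, exchanging fluoro for chloro on the six-membered aromatic ring of carbon only, part of a fused or bridged system of two rings, gives a number 12 percentage points higher from compound 2 to compound 3 (beyond the scatter) and so clears the usual scatter. Going by these compounds alone, the earlier step involved a chloro elsewhere on the molecule, so this is the first sign that the read-out also responds to which halogen sits at this second place, with chloro on the higher side of fluoro in this matched pair. Within the data shown here, the data show only that the number rises, and no separate measurement accounts for that rise.

This single pair cannot show whether the trend continues beyond these two halogens, so a bromo, a methyl, a methoxy, a nitrile or an amine at the same position remains an open question, as does a plain hydrogen there. On these data alone, it also remains open whether the gain from this chloro would carry over to a molecule with the second chloro of compound 1, since the numbers here come from single exchanges made one at a time.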